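The compounds below may be only part of what the source reports. "The series", "measured", "known", "first", "only" and "open" are said of these compounds alone.

Three compounds sharing one core have been measured in a functional assay (aorta) with Rattus norvegicus as the target; a lower number here means that less compound is needed, a higher number that more compound is needed for the effect:

Compound 1 `COc1ccc(-c2nc(/N=C(\N)NC(C)C)sc2-c2ccc(OC)cc2)cc1` gives 9.1 uM
Compound 2 `C/N=C(/NC)Nc1nc(-c2ccc(OC)cc2)c(-c2ccc(OC)cc2)s1` gives 2.4 uM
Compound 3 `COc1ccc(-c2nc(CNC(=O)c3cccnc3)sc2-c2ccc(OC)cc2)cc1` gives 8.2 uM

Compound 2 stands lowest of the three numbers; its nearest neighbour is compound 3, and compound 1 lies furthest, with a 3.4-fold higher number from compound 2 to compound 3 (0.53 log units; beyond the scatter) and a 3.8-fold lower number from compound 1 to compound 2 (0.58 log units; beyond the scatter) both beyond the scatter.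

Compound 4 `COc1ccc(-c2nc(C(=O)N(C)C)sc2-c2ccc(OC)cc2)cc1` is not yet measured. It differs from compound 2 at one spot on the shared core: a group of 5 heavy atoms (3 carbon, 1 nitrogen, 1 oxygen; no ring) in place of a group of 6 heavy atoms (3 carbon, 3 nitrogen; no ring), on an aromatic carbon

For the measured compounds named here, two measured steps bear on this. The step of a 3.4-fold higher number from compound 2 to compound 3 (0.53 log units; beyond the scatter) swaps the same six-atom group out of compound 2 for a carbonyl-containing group, and the step of a 1.1-fold lower number from compound 1 to compound 3 (0.05 log units; within the scatter) shows that this carbonyl-containing group and the seven-atom group of compound 1 land within the scatter of each other. Going by the values given here, both carbonyl-free groups with several nitrogens sit at the low end, while the one carbonyl-bearing group sits higher. Compound 4 also carries a carbonyl and loses both hydrogen-bond donors, so a modest rise in the number is expected, of about a 2.9-fold higher number from compound 2 to compound 4 (0.46 log units; beyond the scatter) in this assay.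

The estimate for compound 4 is therefore 7 uM, with a range from 3 uM to 18 uM.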

Compound 4, concentration for half-maximal effect: 3 uM
Compound 4: the middle estimate sits 2.3-fold (0.37 log units) above what was measured, within the range that was stated.
By their numbers in this assay, from the lowest: compounds 2 and 4 (each within the scatter of the next); then compounds 3 and 1 (each within the scatter of the next).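

In this assay, the change to dimethylcarbamoyl gives a 1.3-fold higher number from compound 2 to compound 4 (0.10 log units; within the scatter), so a group with a carbonyl and no hydrogen-bond donors cannot be told apart from the group of compound 2 on this aromatic carbon. The same group gives a 2.7-fold lower number from compound 3 to compound 4 (0.44 log units; beyond the scatter) and a 3.0-fold lower number from compound 1 to compound 4 (0.48 log units; beyond the scatter), so a carbonyl at this position does not by itself go with the higher numbers, as compound 3 alone had left possible. Among these four compounds, neither kind of group sorts the numbers: the carbonyl groups of compound 3 and compound 4 fall on different sides of the gap, and so do the groups with three nitrogens in compound 1 and compound 2.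

Nothing available here explains these differences. On these data alone, it remains open how much of the result belongs to the carbonyl and how much to the two methyl groups on the amide nitrogen, a question that an unsubstituted carboxamide, a methyl ester or a carboxylic acid on this aromatic carbon would bear on.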